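Trifluoromethoxy in Place of Methyl on a Shared Core

The source may report more compounds than this note shows. Statements on the series, on what has been measured and on what is new or still open speak of the compounds shown alone.

Measured so far:
compound 1 `Cc1ccc(-c2nc3ncccc3o2)cc1`: 5%
compound 2 `c1ccc(-c2nc3cccnc3o2)cc1`: 55%
compound 3 `COc1ccccc1-c1nc2ncccc2o1`: 9%

Of the compounds shown here, three have been tested in a functional assay on the whole organism for inhibition, with Rattus norvegicus as the target, at a dose of 30 mg/kg; on this read-out lower numbers stand for less inhibition and higher numbers for more inhibition at the one dose given (going by the name of the read-out). Compound 1 gives the smallest of the three numbers, 5%. Compound 3, at 9%, lies within the usual scatter of compound 1, so the two cannot be told apart. Among the measured compounds shown here, compound 2 gives 55%, a number far beyond the scatter from compound 1, but its core is arranged differently, so no single step links it to the others.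

The new compound 4 `FC(F)(F)Oc1ccc(-c2nc3ncccc3o2)cc1` keeps the core of compound 1 and changes one group: trifluoromethoxy in place of methyl on an aromatic carbon. The trifluoromethoxy sits on an aromatic carbon of a six-membered aromatic ring of carbon only, para to a group of 9 heavy atoms.

For the measured compounds named here, no measured pair shows a single change of this kind, so the size of the step from compound 1 to compound 4 in this assay rests on little. The change is expected to move the number only slightly, if at all, upward, with a number 10 percentage points higher from compound 1 to compound 4 (within the scatter) as the expected step. Compound 4 is estimated to give 15%, with a likely range from 0% to 45%.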

Compound 4, a percentage reported as inhibition, in the whole organism at one dose (the size of the read-out at that dose, not a potency): 0%
Compound 4: the middle estimate sits 15 percentage points above what was measured; the measured number falls inside the stated range.
By their numbers in this assay, from the lowest: compounds 4, 1 and 3 (each within the scatter of the next); then compound 2.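

In this assay, among the compounds shown here, trifluoromethoxy in place of methyl on an aromatic carbon gives a number 5 percentage points lower from compound 1 to compound 4 (within the scatter), and this is the first single change on this core that can be read. At this place, para to a group of 9 heavy atoms, a group of 5 heavy atoms that counts 1 hydrogen-bond acceptor stands in for a group of 1 heavy atom and 0 hydrogen-bond acceptors, yet the two compounds cannot be told apart. No measurement shown here offers an explanation for this result.

The compounds shown leave open how an amine or a carboxylic acid on the same aromatic carbon would read in this assay, as so far only methyl and trifluoromethoxy have been compared there. Also open, on these data alone, is what plain hydrogen at this place on the core of compound 1 would give, and whether any single change on this core can produce a step beyond the usual scatter.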